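Bromophenyl Position Swap on a Second Dimethoxy Core

This account rests on a few compounds, and the source may have more. Where it says the series, first, only, none or still open, it means among the compounds named here.

Compound 1 `COc1cccc(/C=C2\CCC/C(=C\c3cccc(Br)c3)C2=O)c1OC` and compound 2 `COc1cccc(/C=C2\CCC/C(=C\c3ccc(Br)cc3)C2=O)c1OC` share one core and differ only by 4-bromophenyl in place of 3-bromophenyl on a double-bonded chain carbon bound to a double-bonded ring carbon. In a functional assay on MCF7 cells (Homo sapiens) for cytotoxicity, read by MTT assay, with a stated time of 72 h (on this read-out higher numbers stand for weaker inhibition and lower numbers for stronger inhibition), compound 1 gives 11700 nM, and compound 2 gives 13800 nM; the step is a 1.2-fold higher number from compound 1 to compound 2 (0.07 log units; within the scatter). Compound 3 `COc1ccc(/C=C2\CCC/C(=C\c3cccc(Br)c3)C2=O)cc1OC` carries a core whose difference from that of compound 1 is not broken down here, and in this assay compound 3 gives 5300 nM, the lowest of the three numbers. Compound 4 `COc1ccc(/C=C2\CCC/C(=C\c3ccc(Br)cc3)C2=O)cc1OC` differs from compound 3 by 4-bromophenyl in place of 3-bromophenyl on a double-bonded chain carbon bound to a double-bonded ring carbon, the same change as before. Because the earlier change gave a 1.2-fold higher number from compound 1 to compound 2 (0.07 log units; within the scatter), a step of similar size is expected from compound 3 to compound 4, namely a 1.2-fold higher number from compound 3 to compound 4 (0.08 log units; within the scatter). On that basis compound 4 is estimated to give 6300 nM in this assay, likely between 3000 nM and 13000 nM.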

Compound 4, half-maximal inhibitory concentration: 6900 nM
Compound 4: middle estimate off by 1.1-fold (0.04 log units), on the low side, within the range that was stated.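

In this assay, 4-bromophenyl in place of 3-bromophenyl gives a 1.3-fold higher number from compound 3 to compound 4 (0.11 log units; within the scatter), and the change reads alike on the two cores: the same change on two cores in this assay, a 1.2-fold higher number (0.07 log units; within the scatter) from compound 1 to compound 2 and a 1.3-fold higher number (0.11 log units; within the scatter) from compound 3 to compound 4, 1.1-fold (0.04 log units) apart, within the scatter of two such steps

On both cores, then, the swap gives a step within the scatter, so the two bromophenyl groups cannot be told apart in this assay on either core. This rests on just two pairs, however, and it does not show that the change would carry over in the same way to any other core, nor does it explain why the steps match.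

The compounds shown leave open what would happen with a group other than a bromophenyl on the double-bonded chain carbon. An aminophenyl or a carboxyphenyl group there might or might not give numbers like these.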